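From bromo to 2,6-dimethylphenyl at the assay limit

A few compounds are considered here, and "the series" means these few. Any claim that something is new, unique, unknown or untested is made for them only; others in the source may bear on it.

Compound 1 `CCOC(=O)c1c(-c2cccc(Oc3ccccc3)c2)[nH]c2cc(OC)c(F)cc2c1=O`: > 21500 nM (a limit)
Compound 2 `CCOC(=O)c1c(-c2cccc(Br)c2)[nH]c2cc(OC)c(F)cc2c1=O`: > 21500 nM (a limit)

In an ADME assay on Raji cells (Homo sapiens) for cytotoxicity, read by luminescence, with a stated time of 72 h (a lower number here means that less compound is needed, a higher number that more compound is needed for the effect), compound 2 gives > 21500 nM, which is a limit of the assay and not a number. Among the compounds with values here, its standing is therefore known only roughly, and the whole series so far shows one picture: the limit of > 21500 nM in this assay, at which 2 of the 2 values shown sit.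

Compound 3 `CCOC(=O)c1c(-c2cccc(-c3c(C)cccc3C)c2)[nH]c2cc(OC)c(F)cc2c1=O` keeps the shared core but carries 2,6-dimethylphenyl in place of bromo on an aromatic carbon.

Within the data shown here, one measured step bears on this change, as it concerns the same group of compound 2: a step that the two limits leave unreadable from compound 1 to compound 2. With phenoxy in that place, compound 1 gives > 21500 nM, again a limit. Neither the size nor the direction of any effect can be read from this pair, so no clear step is expected in this assay, although a modest fall in the number remains possible. The expected change is an at least 1.0-fold lower number from compound 2 to compound 3 (0.03 log units; that floor lies within the scatter). For compound 3 the estimated value is 20000 nM, with an expected range of 8000 nM to 30000 nM.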

Compound 3, half-maximal effective concentration: > 21500 nM
Compound 3 gave a limit, no number; the forecaster's own chance of this, stated with the estimate: 75%; middle value at least 1.0-fold (0.03 log units) from the limit.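

In this assay compound 3 gives > 21500 nM, which is a limit and not a number. No step can therefore be read between compound 3 and either compound 1 or compound 2, and the series keeps one picture: the limit of > 21500 nM in this assay, at which 3 of the 3 values shown sit.

The compounds shown leave open how much of each compound the effect would take, and whether the three differ at all.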